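Methoxy for Chloro: Expecting the Number for Compound 4

This account rests on a few compounds, and the source may have more. Where it says the series, first, only, none or still open, it means among the compounds named here.

Compound 3 `N#C[Se]c1ccc(NC(=O)Oc2ccc(Cl)cc2)cc1` stands second highest of the three numbers measured in a functional assay on CCRF-CEM cells (Homo sapiens) for cytotoxicity, read by MTT assay, with a stated time of 72 h (on this read-out higher numbers stand for weaker inhibition of growth and lower numbers for stronger inhibition of growth), where compound 3 gives 18300 nM. Its nearest neighbour is compound 1 `N#C[Se]c1ccc(NC(=O)Oc2ccccc2)cc1`, which in this assay gives 22900 nM; the step of a 1.3-fold lower number from compound 1 to compound 3 (0.10 log units; within the scatter) lies within the scatter. Farthest away is compound 2 `N#C[Se]c1ccc(NC(=O)OCC2=Cc3ccccc3S2(=O)=O)cc1`, which in this assay gives 3300 nM, a number that compound 3 does not approach.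

The new compound 4 `COc1ccc(OC(=O)Nc2ccc([Se]C#N)cc2)cc1` differs from compound 3 in one place: methoxy in place of chloro on an aromatic carbon. Going by the values given here, the only measured step that touches this position, a 1.3-fold lower number from compound 1 to compound 3 (0.10 log units; within the scatter), stayed within the scatter, so a change at this carbon has so far moved the number little. Compound 2 alters a different part of the molecule and gives no guidance here.

Compound 4 is therefore expected to show a step of a 1.0-fold lower number from compound 3 to compound 4 (0.01 log units; within the scatter), not beyond the scatter. For compound 4 the estimate in this assay is 18000 nM, with a range from 8000 nM to 40000 nM.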

Compound 4, concentration for 50% growth inhibition: 13000 nM
Compound 4: the middle estimate sits 1.4-fold (0.14 log units) above what was measured; the range from low to high includes it.
By their numbers in this assay, from the lowest: compound 2; then compounds 4, 3 and 1 (each within the scatter of the next).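

In this assay the same aromatic carbon now carries hydrogen, chloro or methoxy, and both new steps, first a 1.4-fold lower number from compound 3 to compound 4 (0.15 log units; within the scatter) and then a 1.8-fold lower number from compound 1 to compound 4 (0.25 log units; within the scatter), stay within the scatter, as the step from hydrogen to chloro did. Methoxy, with two heavy atoms and one hydrogen-bond acceptor, thus takes the place of chloro, with one heavy atom and no acceptor, without carrying the number beyond the scatter, so this position has now tolerated a second, larger replacement in these compounds. Nothing measured here explains this result.

The compounds shown leave open whether an amine or a carboxylic acid on this carbon would move the number beyond the scatter. They also leave open whether a longer chain in place of methoxy would do so.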